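Extending the chain on the core nitrogen of compound 1

The compounds below may be only part of what the source reports. "The series", "measured", "known", "first", "only" and "open" are said of these compounds alone.

Compound 1 `CCn1c(N)c(-c2nc3ccccc3[nH]2)c2nc(C#N)c(C#N)nc21` carries an ethyl group on an aromatic nitrogen of the shared core. In a functional assay on A549 cells (Homo sapiens) for antiproliferative activity, read by MTT assay, with a stated time of 48 h (on this read-out lower numbers stand for stronger inhibition and higher numbers for weaker inhibition), compound 1 reaches only a limit of the assay, > 50000 nM, so no number stands for it. Compound 2 `CN(C)CCn1c(N)c(-c2nc3ccccc3[nH]2)c2nc(C#N)c(C#N)nc21` likewise reaches only a limit in this assay, > 50000 nM. Compound 3 `CN1CCN(CCn2c(N)c(-c3nc4ccccc4[nH]3)c3nc(C#N)c(C#N)nc32)CC1` gives 40500 nM in this assay. The step from compound 1 to compound 2 is a step that the two limits leave unreadable from compound 1 to compound 2; the step to compound 3 is an at least 1.2-fold lower number from compound 1 to compound 3 (0.09 log units; that floor lies within the scatter), and that from compound 2 to compound 3 is an at least 1.2-fold lower number from compound 2 to compound 3 (0.09 log units; that floor lies within the scatter). Two of the three values sit at the limit of > 50000 nM in this assay, at which 2 of the 3 values shown sit.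

Compound 4 `CCN(CC)CCCCn1c(N)c(-c2nc3ccccc3[nH]2)c2nc(C#N)c(C#N)nc21` differs from compound 1 by 2-(diethylamino)ethyl in place of hydrogen on a saturated chain carbon, two bonds along the chain from an aromatic nitrogen. The two steps that attach a basic amine to this chain, dimethylamino and 4-methylpiperazin-1-yl, leave the read-out at or barely under the limit, so no step beyond the scatter is expected for this change. Compound 4 is therefore expected to give about 45000 nM, within 20000 nM to 100000 nM, and most likely only a limit again. This estimate corresponds to an expected at least 1.1-fold lower number from compound 1 to compound 4 (0.04 log units; that floor lies within the scatter).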

Compound 4, half-maximal inhibitory concentration: 5750 nM
The estimate for compound 4 lay 7.8-fold (0.89 log units) above the measured number; the whole stated range lies above it.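

In this assay, for the compounds shown here, the 2-(diethylamino)ethyl group on this saturated chain carbon gives the first step that clearly exceeds the scatter: an at least 8.6-fold lower number from compound 1 to compound 4 (0.93 log units; beyond the scatter). The other two chains ending in an amine do not match it, as shown by a 7.0-fold lower number from compound 3 to compound 4 (0.85 log units; beyond the scatter) and by an at least 8.6-fold lower number from compound 2 to compound 4 (0.93 log units; beyond the scatter), so among these compounds an amine on the chain does not by itself bring the read-out down to the level of compound 4. Two of these steps are floors, and their full size cannot be read, because compound 1 and compound 2 both stand at a limit: the limit of > 50000 nM in this assay, at which 2 of the 4 values shown sit.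

Compound 4 combines a longer chain with a diethylamino end, and the compounds shown do not separate these two features. A dimethylamino group on a butyl chain, or a morpholine at the end of that chain, would bear on this question.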